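Solubility notes: from compound 2 to compound 3

A few compounds are considered here, and "the series" means these few. Any claim that something is new, unique, unknown or untested is made for them only; others in the source may bear on it.

Among the compounds with values here, in a physicochemical assay for solubility, read by HPLC, with a stated time of 24 h (a higher number here means a more soluble compound, a lower number a less soluble compound), compound 2 `O=C1CNC(=O)N1C[C@H]1CN(c2ccc(-n3cc(-c4ccccn4)cn3)c(F)c2)C(=O)O1` gives 1630000 nM, the only full number. Compound 1 `O=C1O[C@@H](CN2CCC(c3ccc(F)cc3)CC2)CN1c1ccc(-n2cc(-c3ccccn3)cn2)c(F)c1` returns a limit of the assay rather than a number, <= 19400 nM, as noted in the limit of <= 19400 nM in this assay, at which 1 of the 2 values shown sits. Compound 3 `CCC(=O)NC[C@H]1CN(c2ccc(-n3cc(-c4ccccn4)cn3)c(F)c2)C(=O)O1` is not yet measured; against compound 2 it carries propanoylamino in place of 2,5-dioxoimidazolidin-1-yl on a saturated chain carbon bound to a saturated ring carbon. Within the data shown here, no measured step between numbered compounds is available, so the expected step is a modest downward one in this assay, only a little beyond the usual scatter: a 2.0-fold lower number from compound 2 to compound 3 (0.31 log units; beyond the scatter). Compound 3 is accordingly estimated at 800000 nM, with an expected range from 250000 nM to 2000000 nM.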

Compound 3, solubility: 147000 nM
Compound 3: the middle estimate sits 5.4-fold (0.74 log units) above what was measured; measured number below the stated range.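

In this assay, the place on a saturated chain carbon bound to a saturated ring carbon now has its first readable step: propanoylamino in place of 2,5-dioxoimidazolidin-1-yl gives an 11-fold lower number from compound 2 to compound 3 (1.04 log units; beyond the scatter). The read-out therefore responds to the group at this place, and by a large margin. Nothing shown accounts for the size of this step.

The trend rests on this single pair. On these data alone, how a longer acyl chain, an amine or a carboxylic acid at this place would compare with compound 2 and compound 3 remains open.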